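Compound 3 to compound 4: replacing isopropyl

The source may hold more compounds than are shown below. What is called first, only, known or untested is meant among the compounds shown, and "the series" means these compounds.

Measured in a functional assay for inhibition, with Homo sapiens as the target (a lower number here means a stronger inhibitor, a higher number a weaker inhibitor), read as the half-maximal inhibitory concentration:
- compound 1 `CCOC(=O)/C(=C/c1cccc(OCC(=O)OC)c1)c1nc(-c2ccccc2)c(-c2ccccc2)o1`: 19700 nM
- compound 2 `CCOC(=O)/C(=C\c1cccc(OCC(=O)OC(C)(C)C)c1)c1nc(-c2ccccc2)c(-c2ccccc2)o1`: > 60000 nM (a limit, not a number)
- compound 3 `CC(C)C(Cc1cccc(OCC(=O)O)c1)c1nc(-c2ccccc2)c(-c2ccccc2)o1`: 970 nM

Among the numbers in this assay, compound 3 gives the lower one at 970 nM. Compound 1 gives 19700 nM, and the gap between the two lies beyond the usual scatter. Compound 2 reaches only the limit of > 60000 nM.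

The next compound to be tested is compound 4 `O=C(O)COc1cccc(CC(CCCO)c2nc(-c3ccccc3)c(-c3ccccc3)o2)c1`. It carries 3-hydroxypropyl in place of isopropyl on a saturated chain carbon bound to an aromatic carbon and a saturated chain carbon.

Among the compounds with values here, no measured pair differs in one place only, so the data give no direct size for this change. Compounds 1 and 2 differ from compound 3 in more than one place and offer no measure of it. The expectation therefore starts from compound 3 at 970 nM and allows for a modest loss in this assay, with no change beyond the scatter still possible. The expected move is a 2.6-fold higher number from compound 3 to compound 4 (0.41 log units; beyond the scatter), towards a weaker inhibitor. For compound 4 the estimated value is 2500 nM, with an expected range from 600 nM to 10000 nM.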

Compound 4, half-maximal inhibitory concentration: 1700 nM
Compound 4: middle estimate off by 1.5-fold (0.17 log units), on the high side; measured number inside the range.
By their numbers in this assay, from the lowest: compounds 3 and 4 (each within the scatter of the next); then compound 1. At a limit, above all of these: compound 2.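

In this assay, the exchange at this position gives a 1.8-fold higher number from compound 3 to compound 4 (0.24 log units; within the scatter), so isopropyl and 3-hydroxypropyl on a saturated chain carbon bound to an aromatic carbon and a saturated chain carbon cannot be separated by this read-out. Within the data shown here, this is the first one-place comparison: compound 1 and compound 2 differ from compound 3 in more than one place and gave no reading of this carbon, whereas the present pair shows that a longer substituent carrying a hydrogen-bond donor and a hydrogen-bond acceptor can stand here without a step beyond the scatter. No measurement at hand speaks to the reason for this outcome.

As far as these compounds go, only these two groups have been compared at this carbon, so it remains open how far the position accepts other substituents, such as a propyl chain ending in an amine or a carboxylic acid, a longer chain ending in hydroxyl, or a phenyl ring. From the compounds shown here alone, it also remains open whether the two compounds stay inseparable with the carboxylic acid of the oxyacetic acid side chain replaced by a methyl ester or an amide.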